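The source may report more compounds than this note shows. Statements on the series, on what has been measured and on what is new or still open speak of the compounds shown alone.

Measured compounds in an ADME assay on HepG2 cells (Homo sapiens) for cytotoxicity; a higher number here means that more compound is needed for the effect, a lower number that less compound is needed:
Compound 1, `Cc1ccc(S(=O)(=O)N[C@@H](CC(=O)NC(C)(C)C)C(=O)NCCNC(=O)c2cc(C)ccc2F)cc1`: compound 1 gives only the limit of the assay, > 11000 nM.
Compound 2, `Cc1ccc(S(=O)(=O)N[C@@H](CC(=O)NC(C)(C)C)C(=O)NCCNC(=O)c2ccccc2)cc1`: compound 2 also stops at the limit of the assay, > 11000 nM.
Compound 3, `Cc1ccc(S(=O)(=O)N[C@@H](CC(=O)NC(C)(C)C)C(=O)NCCNC(=O)c2cc(C)ccn2)cc1`: compound 3 likewise gives the limit of the assay, > 11000 nM.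

Compound 3 therefore stands at the limit, as do the two other values; all three sit at the limit of > 11000 nM in this assay, at which 3 of the 3 values shown sit. The three steps among them, a step that the two limits leave unreadable from compound 1 to compound 2, a step that the two limits leave unreadable from compound 1 to compound 3 and a step that the two limits leave unreadable from compound 2 to compound 3, each exchange the group on the carbonyl carbon, and the two limits leave every one of them unreadable in size.

Compound 4, `Cc1ccc(S(=O)(=O)N[C@@H](CC(=O)NC(C)(C)C)C(=O)NCCNC(=O)c2ccccc2O)cc1`, differs from compound 3 by 2-hydroxyphenyl in place of 4-methylpyridin-2-yl on a carbonyl carbon. Among the measured compounds shown here, no measured step covers this exact change; what the measured steps do show is that three different groups on the carbonyl carbon all left the value at the limit of this assay. Compound 4 is thus expected to stay at the limit as well, the step that the limit leaves unreadable from compound 3 to compound 4 being an expectation of no readable change. Compound 4 is estimated at 20000 nM, with a range from 11000 nM to 50000 nM.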

Compound 4, half-maximal effective concentration: > 11000 nM
Compound 4 gave a limit, no number (the forecaster's own chance of this, stated with the estimate: 85%); the middle value is on the limit's open side.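

In this assay compound 4 gives only a limit, > 11000 nM, so its steps to compound 1, compound 2 and compound 3 cannot be read in size. All four compounds stand together: the limit of > 11000 nM in this assay, at which 4 of the 4 values shown sit. The compounds shown leave open where any true value lies and whether any exchange on the carbonyl carbon alters it.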